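A few compounds are considered here, and "the series" means these few. Any claim that something is new, unique, unknown or untested is made for them only; others in the source may bear on it.

Compound 1 `COc1ccc2[nH]c(C(=O)N3CC(=O)N(Cc4ccccc4)[C@@H](COc4ccccc4)C3)cc2c1`: in an ADME assay on Vero cells (Chlorocebus sabaeus) for cytotoxicity, with a stated time of 7 days (a lower number here means that less compound is tolerated, a higher number that more compound is tolerated), compound 1 gives > 10000 nM, a limit of the assay.
Compound 2 `COc1ccc2[nH]c(C(=O)N3CC(=O)N(Cc4ccoc4)[C@@H](Cc4ccccc4)C3)cc2c1`: in this assay compound 2 gives > 10000 nM, again a limit.
Compound 3 `COc1ccc2[nH]c(C(=O)N3CC(=O)N(Cc4ccc[nH]4)[C@@H](Cc4ccccc4)C3)cc2c1`: in this assay compound 3 gives 15200 nM.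

Compound 3 thus holds the only number shown; the other two values are limits (the limit of > 10000 nM in this assay, at which 2 of the 3 values shown sit). Among the measured compounds shown here, the one single-point step measured, a step that the limit leaves unreadable from compound 2 to compound 3, cannot be sized for that reason. Compound 4 `COc1ccc2[nH]c(C(=O)N3CC(=O)N(Cc4c[nH]c5ccccc45)[C@@H](Cc4ccccc4)C3)cc2c1` has not been measured; it differs from compound 3 by 1H-indol-3-yl in place of 1H-pyrrol-2-yl on a saturated chain carbon bound to an amide-type nitrogen in a ring. For the measured compounds named here, no measured step bears on this change, so nothing in the data points to a step beyond the scatter in this assay. Compound 4 is therefore expected near 14000 nM, between 6000 nM and 32000 nM. The estimated step of a 1.1-fold lower number from compound 3 to compound 4 (0.04 log units; within the scatter) is expected to stay within the scatter.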

Compound 4, half-maximal cytotoxic concentration: 7200 nM
For compound 4 the middle estimate is 1.9-fold (0.29 log units) above the measured one; the range from low to high includes it.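

In this assay, among the compounds shown here, the change from 1H-pyrrol-2-yl to 1H-indol-3-yl gives the first readable step at this position: a 2.1-fold lower number from compound 3 to compound 4 (0.32 log units; beyond the scatter). With the added six-membered aromatic ring of carbon only, less compound is tolerated here. Against furan-3-yl the change gives only a floor, an at least 1.3-fold lower number from compound 2 to compound 4 (0.14 log units; that floor lies within the scatter), and compound 2 stands at a limit: the limit of > 10000 nM in this assay, at which 2 of the 4 values shown sit.

This change alters both the ring count and the point of attachment, and the compounds shown do not separate the two. From the compounds shown here alone, how a pyridine ring or a carboxylic acid at this place would read in this assay also stays open.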